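The source may hold more compounds than are shown below. What is called first, only, known or untested is meant among the compounds shown, and "the series" means these compounds.

Measured so far:
compound 1 `CCOC(=O)/C(C)=C/C1=CC[C@H]2C(C)(C)CCC[C@]2(C)[C@H]1C=O` gives 28000 nM
compound 2 `CC(C)(C)OC(=O)/C=C/C1=CC[C@H]2C(C)(C)CCC[C@]2(C)[C@H]1C=O` gives 29000 nM

In a functional assay on Hs 683 cells (Homo sapiens) for inhibition, read by MTT assay, with a stated time of 72 h (on this read-out higher numbers stand for weaker inhibition of growth and lower numbers for stronger inhibition of growth), compound 2 gives 29000 nM and stands level with compound 1, the two values lying within the usual scatter of each other. Going by the values given here, these are the only measurements available, and no measured pair shows the change considered next. Compound 3 `CC(=O)/C=C/C1=CC[C@H]2C(C)(C)CCC[C@]2(C)[C@H]1C=O` carries methyl in place of tert-butoxy on a carbonyl carbon so that tert-butoxycarbonyl becomes acetyl. Among the compounds with values here, with compound 1 at 28000 nM and compound 2 at 29000 nM as the only guides, no step beyond the scatter is expected in this assay and no direction can be favoured with confidence. The estimated step of a 1.2-fold lower number from compound 2 to compound 3 (0.06 log units; within the scatter) is therefore small. For compound 3 the expected value is 25000 nM (with a range of 10000 nM to 60000 nM).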

Compound 3, concentration for 50% growth inhibition: 22000 nM
Beside the measured number, compound 3's estimate is 1.1-fold (0.06 log units) above it; low and high end bracket the measured number.
By their numbers in this assay, from the lowest: compounds 3, 1 and 2 (each within the scatter of the next).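

In this assay, going by these compounds alone, putting methyl in place of tert-butoxy on the carbonyl carbon, so that tert-butoxycarbonyl becomes acetyl, gives a 1.3-fold lower number from compound 2 to compound 3 (0.12 log units; within the scatter) and offers the first direct reading of a change at this position. The group at this place can go from 5 heavy atoms to 1, and lose its oxygen, without any change that can be told apart from the scatter of the measurement. No other measurement here helps to interpret this flat result.

From the compounds shown here alone, it remains open whether a carboxylic acid or an amide at this carbonyl carbon would move the number beyond the scatter. A chain longer than methyl but without the oxygen, such as ethyl or propyl, is also untested among the compounds shown, so the limits of this tolerance remain unknown.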